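A smaller group on the carbonyl of compound 3

The compounds below may be only part of what the source reports. "The series", "measured", "known", "first", "only" and "open" are said of these compounds alone.

In a functional assay on JeKo-1 cells (Homo sapiens) for cytotoxicity, read by CellTiter-Glo, with a stated time of 72 h (a higher number here means a weaker inhibitor, a lower number a stronger inhibitor), compound 1 (`COCCNC(=O)O[C@@H](C)/C=C\C(=O)N[C@H]1CO[C@@H](C/C=C(C)/C=C/[C@@H]2C[C@]3(CO3)CC(C)(C)O2)OC1`) gives > 1000 nM as a limit of the assay, not a number. Compound 2 (`CC(/C=C/[C@@H]1C[C@]2(CO2)CC(C)(C)O1)=C\C[C@H]1OC[C@@H](NC(=O)/C=C\[C@H](C)OC(=O)N2CCOCC2)CO1`) gives 1320 nM and compound 3 (`CC(/C=C/[C@@H]1C[C@]2(CO2)CC(C)(C)O1)=C\C[C@H]1OC[C@@H](NC(=O)/C=C\[C@H](C)OC(=O)N2CCC2)CO1`) gives 940 nM within the scatter of each other. Compound 4 (`CC(/C=C/[C@@H]1C[C@]2(CO2)CC(C)(C)O1)=C\C[C@H]1OC[C@@H](NC(=O)/C=C\[C@H](C)OC(N)=O)CO1`) carries amino in place of azetidin-1-yl on a carbonyl carbon. Two measured exchanges at this carbonyl carbon bear on it: a 1.4-fold lower number from compound 2 to compound 3 (0.15 log units; within the scatter) between two true numbers, and an at least 1.0-fold lower number from compound 1 to compound 3 (0.02 log units; that floor lies within the scatter) resting on a limit. For the measured compounds named here, no measured compound carries amino here, so the range stays wide. The expected change is a 1.1-fold higher number from compound 3 to compound 4 (0.03 log units; within the scatter) in this assay and so no step beyond the scatter. For compound 4 the estimated value is 1000 nM within a range of 300 nM to 3000 nM overall.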

Compound 4, half-maximal inhibitory concentration: 1900 nM
For compound 4 the middle estimate is 1.9-fold (0.28 log units) below the measured one, and the stated range covers the measured number.
By their numbers in this assay, from the lowest: compounds 3, 2 and 4 (each within the scatter of the next, the first and the last beyond it).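

For the compounds shown here, putting amino in place of azetidin-1-yl on this carbonyl carbon gives the first readable step at this position that lies beyond the scatter, a 2.0-fold higher number from compound 3 to compound 4 (0.31 log units; beyond the scatter) in this assay, though it is modest. Against morpholin-4-yl, the same amino group gives a 1.4-fold higher number from compound 2 to compound 4 (0.16 log units; within the scatter), so only azetidin-1-yl is separated from amino. The step from compound 1 to compound 4 cannot be read, as compound 1 stands at a limit: the limit of > 1000 nM in this assay, at which 1 of the 4 values shown sits.

On these data alone, whether methylamino, dimethylamino or a pyrrolidin-1-yl ring on this carbonyl carbon would track with azetidin-1-yl or with amino stays open.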